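A Methoxy Group Added to Compound 2

The compounds below may be only part of what the source reports. "The series", "measured", "known", "first", "only" and "open" are said of these compounds alone.

compound 1 `Fc1ccc(/C=C\c2cc3ccc(Cl)cc3nc2Cl)cc1` 10900 nM
compound 2 `FC(F)(F)c1cccc(/C=C\c2cc3ccccc3nc2Cl)c1` 3700 nM
compound 3 `FC(F)(F)c1cccc(/C=C/c2cc3ccccc3nc2Cl)c1` 24000 nM

These values come from a functional assay on MDA-MB-468 cells (Homo sapiens) for antiproliferative activity, read by sulforhodamine B assay, with a stated time of 72 h; a higher number here means a weaker inhibitor, a lower number a stronger inhibitor. Of the three, compound 2 has the lowest number, 3700 nM. Compound 4 `COc1ccc2nc(Cl)c(/C=C\c3cccc(C(F)(F)F)c3)cc2c1` differs from it by methoxy in place of hydrogen on an aromatic carbon, with methoxy in place of hydrogen on an aromatic carbon. Among the measured compounds shown here, the only measured step, a 6.5-fold higher number from compound 2 to compound 3 (0.81 log units; beyond the scatter), rests on (the fact that compounds 2 and 3 differ only in the configuration as drawn). It adds no group, so it offers little guidance here. For the measured compounds named here, with no measured example of such an addition, no direction can be read, and the best guess is no step beyond the scatter, with wide uncertainty. The expected step is a 1.1-fold higher number from compound 2 to compound 4 (0.03 log units; within the scatter). Compound 4 is estimated at 4000 nM, with an expected range of 1200 nM to 14000 nM.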

Compound 4, half-maximal inhibitory concentration: 3910 nM
The estimate for compound 4 lay 1.0-fold (0.01 log units) above the measured number; low and high end bracket the measured number.
By their numbers in this assay, from the lowest: compounds 2 and 4 (each within the scatter of the next); then compound 1; then compound 3.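

In this assay the swap of hydrogen for methoxy gives a 1.1-fold higher number from compound 2 to compound 4 (0.02 log units; within the scatter) so this aromatic carbon of the fused system carries the added group with no change beyond the scatter. Among the compounds shown here, none of the earlier steps added a group, so this is the first reading of such a change. Nothing on hand explains this outcome. Going by these compounds, whether an amine, a carboxylic acid or a longer chain on this carbon would behave the same stays open. So does whether methoxy would do the same with the E double bond of compound 3.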